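A few compounds are considered here, and "the series" means these few. Any claim that something is new, unique, unknown or untested is made for them only; others in the source may bear on it.

Compound 1 `Cn1cc(-c2cc(C(O)(C(F)(F)F)C(F)(F)F)cnc2N2CCN(S(=O)(=O)c3ccc(N)nc3)CC2)cn1`: 19 mL.min-1.g-1
Compound 2 `CS(=O)(=O)Nc1cccc(-c2cc(C(O)(C(F)(F)F)C(F)(F)F)cnc2N2CCN(S(=O)(=O)c3ccc(N)nc3)CC2)c1`: 40 mL.min-1.g-1
Compound 3 `COc1ccc(-c2cc(C(O)(C(F)(F)F)C(F)(F)F)cnc2N2CCN(S(=O)(=O)c3ccc(N)nc3)CC2)cn1`: 25 mL.min-1.g-1

These three compounds share one core and differ only in the group on a single aromatic carbon. All were tested in an ADME assay (liver) for metabolic stability, with Liver microsome (Homo sapiens) as the target, using microsomes and NADPH, with a stated time of 30 min, tested at 1 uM; a higher number here means faster removal of the compound, a lower number slower removal. In that assay compound 3, at 25 mL.min-1.g-1, lies within the scatter of both other compounds. The two steps that reach it are a 1.3-fold higher number from compound 1 to compound 3 (0.12 log units; within the scatter) and a 1.6-fold lower number from compound 2 to compound 3 (0.20 log units; within the scatter).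

Compound 4 `Nc1ccc(S(=O)(=O)N2CCN(c3ncc(C(O)(C(F)(F)F)C(F)(F)F)cc3-c3ccc4[nH]ncc4c3)CC2)cn1` has not yet been measured. It carries 1H-indazol-5-yl in place of 6-methoxypyridin-3-yl on an aromatic carbon, the same carbon where the measured compounds differ: 1H-indazol-5-yl in place of 6-methoxypyridin-3-yl on an aromatic carbon. All three measured steps therefore bear on this change, since each swaps the group at that carbon. Only one goes beyond the scatter, and it is modest: a 2.1-fold higher number from compound 1 to compound 2 (0.32 log units; beyond the scatter). For the measured compounds named here, none of the measured compounds carries 1H-indazol-5-yl, so this is a comparison with other groups and not a direct precedent.

On that basis, no step beyond the scatter is expected, and the estimated step is a 1.2-fold higher number from compound 3 to compound 4 (0.08 log units; within the scatter). The range is kept wider than the spread of the measured values. For compound 4 the estimated value is 30 mL.min-1.g-1, with an expected range from 14 mL.min-1.g-1 to 60 mL.min-1.g-1.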

Compound 4, intrinsic clearance in microsomes: 27 mL.min-1.g-1
Compound 4: the middle estimate sits 1.1-fold (0.05 log units) above what was measured; the range from low to high includes it.
By their numbers in this assay, from the lowest: compounds 1, 3, 4 and 2 (each within the scatter of the next, the first and the last beyond it).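

In this assay the change at this carbon, which is ortho to a large group, replaces the single six-membered ring of 6-methoxypyridin-3-yl with the two fused rings of 1H-indazol-5-yl and adds a hydrogen-bond donor, yet the number stays within the scatter (a 1.1-fold higher number from compound 3 to compound 4 (0.03 log units; within the scatter)). For the compounds shown here, the comparisons with the other two groups also stay within the scatter (a 1.5-fold lower number from compound 2 to compound 4 (0.17 log units; within the scatter); a 1.4-fold higher number from compound 1 to compound 4 (0.15 log units; within the scatter)), so compound 4 cannot be told apart from any of the earlier compounds in this measurement. Going by these compounds alone, a differently built group has therefore been added at this position, and the only pair beyond the scatter is still the earlier one, and only modestly so (a 2.1-fold higher number from compound 1 to compound 2 (0.32 log units; beyond the scatter)).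

Nothing shown here explains why these four groups give such similar numbers. As far as these compounds go, all four compounds carry an aromatic ring at this carbon, so it remains open how this assay would respond to a non-aromatic group here, such as an amine or a longer alkyl chain, or to a carboxylic acid on the aromatic ring.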